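Methyl to Methoxy on the Anilide Ring of a Shared Core

The compounds below may be only part of what the source reports. "The series", "measured", "known", "first", "only" and "open" are said of these compounds alone.

Of the compounds shown here, three built on one shared core have been tested in a functional assay on the whole organism for inhibition, with Rattus norvegicus as the target, read by paw edema, at a dose of 100 mg/kg by the oral route; a lower number here means less inhibition, a higher number more inhibition at the dose given (going by the name of the read-out). Compound 1 `Cc1ccc(NC(=O)c2c(O)c3cccnc3n(-c3ccccc3)c2=O)cc1` gives -3.5%. Compound 2 `COc1ccc(NC(=O)c2c(O)c3cccnc3n(-c3ccccc3)c2=O)cc1` gives 0.3%; the change from compound 1 to compound 2 is methoxy in place of methyl on an aromatic carbon, and the step it made is a number 3.8 percentage points higher from compound 1 to compound 2 (within the scatter). Compound 3 `Cc1ccccc1NC(=O)c1c(O)c2cccnc2n(-c2ccccc2)c1=O` gives 11.7%, the highest of the three values. The cores of compound 1 and compound 3 differ by 2-methylphenyl in place of 4-methylphenyl on an amide-type nitrogen, and the step is a number 15.2 percentage points higher from compound 1 to compound 3 (beyond the scatter). The step of a number 11.4 percentage points higher from compound 2 to compound 3 (beyond the scatter) is of similar size.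

Compound 4 `COc1ccccc1NC(=O)c1c(O)c2cccnc2n(-c2ccccc2)c1=O` has not yet been measured. It differs from compound 3 by methoxy in place of methyl on an aromatic carbon. Among the measured compounds shown here, this is the same kind of change as the one made from compound 1 to compound 2, but not the same: in the earlier pair the group sits para to a large group, whereas in compound 4 it sits ortho to a large group. Because a number 3.8 percentage points higher from compound 1 to compound 2 (within the scatter) stayed within the scatter, a step of about the same small size is expected here, namely a number 2.3 percentage points higher from compound 3 to compound 4 (within the scatter). Compound 4 is therefore estimated to give 14% in this assay. The expected range for compound 4 runs from 0% to 28%, wide because a number 3.8 percentage points higher from compound 1 to compound 2 (within the scatter) rests on a single measured pair at a different place on the ring.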

Compound 4, a percentage reported as inhibition, in the whole organism at one dose (the size of the read-out at that dose, not a potency): 8.1%
The estimate for compound 4 lay 5.9 percentage points above the measured number; the measured number falls inside the stated range.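

In this assay, methoxy in place of methyl, ortho to a large group, gave a number 3.6 percentage points lower from compound 3 to compound 4 (within the scatter), and this change carried between the two cores without a measurable difference: the same change on two cores in this assay, a number 3.8 percentage points higher (within the scatter) from compound 1 to compound 2 and a number 3.6 percentage points lower (within the scatter) from compound 3 to compound 4, 7.4 percentage points apart, within the scatter of two such steps. Among the related steps, 2-methoxyphenyl in place of 4-methoxyphenyl gave a number 7.8 percentage points higher from compound 2 to compound 4 (within the scatter), while 2-methoxyphenyl in place of 4-methylphenyl gave a number 11.6 percentage points higher from compound 1 to compound 4 (beyond the scatter), so only the latter clears the scatter. This does not show that the change has no effect or that it would behave alike on a further core, as two pairs with steps inside the scatter cannot separate a small real effect from none.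

The compounds shown leave open whether another group at the same place on the anilide ring, such as chloro, an amine or a carboxylic acid, would give a step beyond the scatter where methyl and methoxy did not. They also leave open how these compounds would compare at any other dose, and whether the phenyl group on the ring nitrogen of the shared core could be replaced by a longer chain.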